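Methoxy Enters Where Hydrogen Stood on the Phenyl Ring

The compounds below may be only part of what the source reports. "The series", "measured", "known", "first", "only" and "open" are said of these compounds alone.

Compound 1 `Fc1ccc(C2CC(c3ccc(Cl)s3)=NN2c2nc(-c3ccc(Cl)cc3)cs2)cc1` gives 125 ug/mL in a functional assay on A549 cells (Homo sapiens) for antiproliferative activity, read by XTT assay, with a stated time of 24 h; on this read-out lower numbers stand for stronger inhibition and higher numbers for weaker inhibition. Compound 2 `Fc1ccc(C2CC(c3ccc(Cl)s3)=NN2c2nc(-c3ccccc3)cs2)cc1` reaches only the limit of the assay, > 500 ug/mL in this assay. Among the compounds with values here, the single measured step, an at least 4.0-fold higher number from compound 1 to compound 2 (0.60 log units; beyond the scatter), rests on the limit of > 500 ug/mL in this assay, at which 1 of the 2 values shown sits, and is the only guide here. Compound 3 `COc1ccc(-c2csc(N3N=C(c4ccc(Cl)s4)CC3c3ccc(F)cc3)n2)cc1` differs from compound 2 by methoxy in place of hydrogen on an aromatic carbon, a methoxy in place of hydrogen on an aromatic carbon, para to a large group. Within the data shown here, no measured step involves a methoxy group. The change an at least 1.2-fold lower number from compound 2 to compound 3 (0.09 log units; that floor lies within the scatter) is expected to stay within the scatter. Compound 3 is therefore estimated at 400 ug/mL in this assay, between 150 ug/mL and 1000 ug/mL, with a fair chance that only a limit is reported.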

Compound 3, half-maximal inhibitory concentration: > 500 ug/mL
Compound 3 was reported as a limit; the forecaster's own chance of this, stated with the estimate: 55%; at least 1.2-fold (0.09 log units) between middle value and limit.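

On this phenyl position, para to a large group, chloro has now been compared with two other groups, not one: methoxy in place of chloro gives an at least 4.0-fold higher number from compound 1 to compound 3 (0.60 log units; beyond the scatter) in this assay, so compound 1 remains the only one of the three with a readable value. The step between compound 2 and compound 3 cannot be read because both values are limits: the limit of > 500 ug/mL in this assay, at which 2 of the 3 values shown sit.

Going by these compounds, whether methoxy improves on hydrogen at all stays open. Also open, on these data alone, is whether an amine or a carboxylic acid at this position would give a readable value.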